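Methoxy to methyl on the pyridine of a bicyclic core

A few compounds are considered here, and "the series" means these few. Any claim that something is new, unique, unknown or untested is made for them only; others in the source may bear on it.

Measured compounds:
compound 1, `CC[C@H](C)[C@@H]1C(=O)N[C@H](C2Cc3ccccc3C2)C(=O)N1[C@@H](C(=O)N(C)C)c1ccc(C)[n+]([O-])c1`, 1 nM
compound 2, `COc1ccc([C@H](C(=O)N(C)C)N2C(=O)[C@@H](C3Cc4ccccc4C3)NC(=O)[C@H]2CC(C)C)cn1`, 0.398 nM

Both compounds were run in an assay on isolated protein for displacement of a labelled ligand from Oxytocin receptor (Homo sapiens); a lower number here means a stronger inhibitor, a higher number a weaker inhibitor. Compound 2 gives the lower of the two numbers in this assay, and compound 1 sits above it by a margin that lies beyond the usual scatter. Compound 1 and compound 2 differ in more than one place, so their pair is read only by what the two values show.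

Compound 3, `Cc1ccc([C@H](C(=O)N(C)C)N2C(=O)[C@@H](C3Cc4ccccc4C3)NC(=O)[C@H]2CC(C)C)cn1`, is not yet measured. It differs from compound 2 in one place: methyl in place of methoxy on an aromatic carbon

Among the compounds with values here, no step between measured compounds is on record for this change, so there is no direct precedent. The change is small in size, a methoxy swapped for a methyl on the same aromatic carbon, and a step near the scatter or somewhat toward weaker binding is expected; the step from compound 2 to compound 3 in this assay is estimated at a 1.8-fold higher number from compound 2 to compound 3 (0.25 log units; within the scatter).

For compound 3 in this assay the estimate is 0.7 nM, with a range from 0.25 nM to 2 nM.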

Compound 3, inhibition constant in the Oxytocin receptor assay: 1.59 nM
Estimate against measurement, compound 3: 2.3-fold (0.36 log units) below; low and high end bracket the measured number.
By their numbers in the Oxytocin receptor assay, from the lowest: compound 2; then compounds 1 and 3 (each within the scatter of the next).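

Within the data shown here, this is the first single-place step at this position, on an aromatic carbon next to the ring nitrogen, and it shows that the position is not indifferent to the group it carries: in the Oxytocin receptor assay, going from 6-methoxypyridin-3-yl to 6-methylpyridin-3-yl gives a 4.0-fold higher number from compound 2 to compound 3 (0.60 log units; beyond the scatter), so binding weakens beyond the scatter with methyl in place of methoxy. In a physicochemical assay for solubility, read by HPLC (on this read-out lower numbers stand for lower solubility and higher numbers for higher solubility), compound 2 gives 216 ug/mL. In the physicochemical assay, compound 3 gives > 236 ug/mL, which is a limit of the assay and not a number, so the step in solubility for this change cannot be read: the limit of > 236 ug/mL in the physicochemical assay, at which 1 of the 2 values shown sits.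

Still open, as far as these compounds go, is whether the weaker binding follows from losing the oxygen of the methoxy or from something else about the methyl, since an ethoxy, a hydroxyl or a dimethylamino group on the same aromatic carbon would be needed to separate these readings. Among these compounds, also open is whether the step carries over to other substituents on the shared core, as only this one pair speaks to the change.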